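The source may report more compounds than this note shows. Statements on the series, on what has been measured and on what is new or still open speak of the compounds shown alone.

Compound 1 `COc1ccc(C2=NN(C3=NC(=O)/C(=C4\C(=O)Nc5ccc(Br)cc54)S3)C(c3ccc(OC)cc3)C2)cc1` and compound 2 `COc1ccc(C2=NN(C3=NC(=O)/C(=C4\C(=O)Nc5ccc(Cl)cc54)S3)C(c3ccc(OC)cc3)C2)cc1` share one core, while compound 3 `CN(C)c1ccc(C2CC(c3ccccc3)=NN2C2=NC(=O)/C(=C3\C(=O)Nc4ccc(Br)cc43)S2)cc1` and compound 4 `CN(C)c1ccc(C2CC(c3ccccc3)=NN2C2=NC(=O)/C(=C3\C(=O)Nc4ccc(Cl)cc43)S2)cc1` share another; the difference between the two cores is not broken down here. In a functional assay on cells (Leukemia cell, Homo sapiens) for cytotoxicity, read by sulforhodamine B assay, with a stated time of 48 h (a higher number here means a weaker inhibitor of growth, a lower number a stronger inhibitor of growth), compound 1 gives 62700 nM, and compound 2 gives 75200 nM. The change between them is chloro in place of bromo on an aromatic carbon, and it made a step of a 1.2-fold higher number from compound 1 to compound 2 (0.08 log units; within the scatter). Compound 3, in this assay, gives 1290 nM, the lowest of the three numbers and beyond the scatter from both compound 1 and compound 2. Compound 4 carries the same change on the core of compound 3: chloro in place of bromo on an aromatic carbon. Because the step of a 1.2-fold higher number from compound 1 to compound 2 (0.08 log units; within the scatter) stayed within the scatter, the same change on the other core is expected to give compound 4 a similarly small step, a 1.2-fold higher number from compound 3 to compound 4 (0.07 log units; within the scatter), though this rests on a single measured pair. Compound 4 is therefore estimated to give about 1500 nM in this assay, likely between 700 nM and 3500 nM.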

Compound 4, concentration for total growth inhibition: 3110 nM
Compound 4: the middle estimate sits 2.1-fold (0.32 log units) below what was measured, and the stated range covers the measured number.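

In this assay, chloro in place of bromo on an aromatic carbon gives a step of a 2.4-fold higher number from compound 3 to compound 4 (0.38 log units; beyond the scatter), and this step does not differ measurably from the one seen on the other core: the same change on two cores in this assay, a 1.2-fold higher number (0.08 log units; within the scatter) from compound 1 to compound 2 and a 2.4-fold higher number (0.38 log units; beyond the scatter) from compound 3 to compound 4, 2.0-fold (0.30 log units) apart, within the scatter of two such steps Within this series, then, the change carries over from one core to the other without a difference that can be told apart, even though only the newer step lies beyond the scatter. This does not show that the two steps are equal in size or that the change would behave alike on any further core, since the comparison rests on just two pairs in a single assay, and it gives no reason for either step.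

The compounds shown leave open how a fluoro, a methoxy or a nitrile group, or a plain hydrogen, would read on the same aromatic carbon. They also leave open which part of the difference between the two cores, such as the dimethylamino group or the methoxy groups, accounts for the gap in growth inhibition.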